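The source may report more compounds than this note shows. Statements on the series, on what has been measured and on what is new or still open speak of the compounds shown alone.

Measured compounds:
Compound 1 `COc1ccc2nc(Nc3ccnc(Nc4ccc(S(N)(=O)=O)cc4)n3)sc2c1`: in a functional assay on PC-3 cells (Homo sapiens) for antiproliferative activity, read by MTT assay, with a stated time of 48 h (on this read-out higher numbers stand for weaker inhibition and lower numbers for stronger inhibition), compound 1 gives 3030 nM.
Compound 2 `NS(=O)(=O)c1ccc(Nc2ncc(F)c(Nc3nc4ccccc4s3)n2)cc1`: in this assay compound 2 gives > 50000 nM, which is a limit of the assay and not a number.
Compound 3 `Cc1ccc2nc(Nc3ccnc(Nc4ccc(S(C)(=O)=O)cc4)n3)sc2c1`: in this assay compound 3 gives > 50000 nM, again a limit of the assay and not a number.

For the measured compounds named here, compound 1 therefore stands alone as the one compound here with a measured number; the other two sit at the limit of > 50000 nM in this assay, at which 2 of the 3 values shown sit. Going by the values given here, no two of these measured compounds differ in only one place, so no measured step of known size exists to lean on.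

Compound 4 `NS(=O)(=O)c1ccc(Nc2nccc(Nc3nc4ccc(F)cc4s3)n2)cc1` is the next compound to be measured in this assay. It differs from compound 1 by fluoro in place of methoxy on an aromatic carbon, the change sitting on an aromatic carbon of the shared core of compound 1. Among the compounds with values here, the methoxy is exchanged for a smaller group with no hydrogen-bond acceptor, and nothing among the measured compounds tells how that exchange moves the read-out.

Within the data shown here, with no measured step to calibrate against, compound 4 is expected to shift from compound 1 by a 2.0-fold higher number from compound 1 to compound 4 (0.30 log units; within the scatter) in this assay, a step of modest size toward weaker inhibition that may well fall within the usual scatter. Compound 4 is thus estimated at 6000 nM in this assay, with a plausible range from 1500 nM to 30000 nM.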

Compound 4, half-maximal inhibitory concentration: 920 nM
For compound 4 the middle estimate is 6.5-fold (0.81 log units) above the measured one; measured number outside the range, below it.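

For the compounds shown here, the swap at this aromatic carbon of the shared core is the first single change that can be read in this assay, and it gives a 3.3-fold lower number from compound 1 to compound 4 (0.52 log units; beyond the scatter), a step beyond the scatter. It shows that this position is not indifferent to what it carries, and that the methoxy, with its hydrogen-bond acceptor, is not required for a measurable read-out, since the smaller fluoro, which has no such acceptor, keeps a measured number and goes with the stronger inhibition of the pair. Compound 4 also joins compound 1 as a second compound with a real number, which sets this pair apart from the values that are only a limit of the assay: the limit of > 50000 nM in this assay, at which 2 of the 4 values shown sit.

This single pair cannot say why fluoro goes with the lower number, nor whether chloro, a hydroxyl, an amine or an ethoxy at the same carbon would side with fluoro or with methoxy. As far as these compounds go, compound 2 and compound 3 each differ from compound 4 in more than one place, so what separates them from the measured pair also stays open.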